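The compounds below may be only part of what the source reports. "The series", "measured", "known", "first", "only" and "open" are said of these compounds alone.

Of the compounds shown here, three of one series have been measured so far. Compound 1 `Cc1ccc(-c2csc(N/N=C/c3cccs3)n2)cc1` and compound 3 `COC(=O)c1cc(-c2csc(N/N=C/c3cccs3)n2)ccc1OCc1ccccc1` share a thiophene-bearing hydrazone end, whereas compound 2 `Clc1ccc(/C=N/Nc2nc(-c3ccccc3)cs2)c(Cl)c1` carries a dichlorophenyl on the hydrazone and an unsubstituted phenyl on the other side of the shared core. In a functional assay, read by spectrophotometry, with a stated time of 15 min, tested at 20 ug/mL (on this read-out higher numbers stand for a stronger effect at the one concentration tested and lower numbers for a weaker effect), compound 1 gives 90.9%, compound 3 gives 94.3%, and compound 2 gives 76.6%. Compound 2 therefore stands lowest of the three numbers: its nearest neighbour is compound 1, a number higher by more than the scatter, and compound 3 lies further still, also beyond the scatter.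

The next compound, compound 4 `Clc1ccc(-c2csc(N/N=C/c3ccc(Cl)cc3Cl)n2)cc1`, has not yet been tested. It differs from compound 2 in one place: chloro in place of hydrogen on an aromatic carbon. The site is on an aromatic carbon of a six-membered aromatic ring of carbon only, para to a large group, so that the phenyl becomes a 4-chlorophenyl. Going by the values given here, no pair among the measured compounds shows this same change, so there is no measured step to lean on. On that basis a small step in this assay is expected, upward if anything, and the step from compound 2 to compound 4 is estimated at a number 3.4 percentage points higher from compound 2 to compound 4 (within the scatter), a movement that might well stay within the scatter. Compound 4 is thus expected to give about 80%, with a range from 65% to 92%.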

Compound 4, a percentage reported as inhibition, at one concentration (the size of the read-out at that concentration, not a potency): 73.9%
The estimate for compound 4 lay 6.1 percentage points above the measured number; the range from low to high includes it.
By their numbers in this assay, from the lowest: compounds 4 and 2 (each within the scatter of the next); then compounds 1 and 3 (each within the scatter of the next).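

In this assay, putting chloro in place of hydrogen, which turns the phenyl into a 4-chlorophenyl, gives a number 2.7 percentage points lower from compound 2 to compound 4 (within the scatter), so the two compounds cannot be told apart at the one concentration tested. Going by these compounds alone, this is the first step that isolates a single change, since the earlier compounds all differed in more than one place, and it shows that a chloro on this aromatic carbon, para to a large group, has no effect that can be read beyond the scatter when the dichlorophenyl stays on the hydrazone. No supporting evidence bears on this result, and a single pair offers no explanation for it.

The compounds shown leave open whether the same change would also fall within the scatter with the thiophene on the hydrazone, which is the end carried by the two compounds with the higher numbers. They also leave open whether this place tolerates other groups in the same way, such as an amine, a carboxylic acid or a longer chain like butyl, since chloro is the only replacement for hydrogen seen here.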